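The source may report more compounds than this note shows. Statements on the series, on what has been measured and on what is new or still open speak of the compounds shown alone.

In a physicochemical assay for lipophilicity, read by HPLC, at pH 7.4 (on this read-out higher numbers stand for higher lipophilicity and lower numbers for lower lipophilicity), the compounds stand as follows:

- Compound 1 `CCc1cc2oc(=O)n(CCC(=O)O)c2cc1Cl`: 1.94
- Compound 2 `O=C(O)CCn1c(=O)oc2cc(OCC3CC3)c(Cl)cc21`: 2.09
- Compound 3 `CCOc1cc2oc(=O)n(CCC(=O)O)c2cc1Cl`: not yet measured

The two measured numbers lie within the scatter of each other, and compound 2 therefore holds no clear rank against compound 1. The structural change that leads to compound 3 is methyl in place of cyclopropyl on a saturated chain carbon bound to an oxygen on an aromatic ring. In words, this is methyl in place of cyclopropyl on a saturated chain carbon bound to an oxygen on an aromatic ring, or cyclopropylmethoxy to ethoxy.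

For the measured compounds named here, only one measured step bears on this change, and only indirectly: a number 0.15 log units higher from compound 1 to compound 2 (within the scatter), with cyclopropylmethoxy in place of ethyl on an aromatic carbon. Going by the values given here, that step involves the same cyclopropylmethoxy group but a different replacement, and no ethoxy compound has yet been measured in this assay. Starting from the 2.09 of compound 2, a modest fall is expected with the smaller group, though its size is uncertain. The expected change is a number 0.34 log units lower from compound 2 to compound 3 (beyond the scatter), as an estimate. For compound 3 the estimated value is 1.75, with an expected range from 1.5 to 2.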

Compound 3, distribution coefficient: 1.49
Beside the measured number, compound 3's estimate is 0.26 log units above it, and the stated range ends above it.
By their numbers in this assay, from the lowest: compound 3; then compounds 1 and 2 (each within the scatter of the next).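

In this assay, methyl in place of cyclopropyl, which turns cyclopropylmethoxy into ethoxy, comes with a number 0.60 log units lower from compound 2 to compound 3 (beyond the scatter) and shows that a change on this saturated chain carbon bound to an oxygen on an aromatic ring can move the read-out beyond the scatter. Ethoxy in place of ethyl on an aromatic carbon comes with a number 0.45 log units lower from compound 1 to compound 3 (beyond the scatter) whereas cyclopropylmethoxy in place of ethyl comes with a number 0.15 log units higher from compound 1 to compound 2 (within the scatter) so whether replacing ethyl with an oxygen-linked group gives a step beyond the scatter depends, among these compounds, on what that chain carbon carries. Nothing among the data offered here gives a reason for either step.

The compounds shown leave open whether the step from compound 2 to compound 3 goes with the loss of the three-membered ring or with the loss of carbon atoms, a question that a propyl group on the same chain carbon would bear on. They also leave open how far the read-out follows the chain in either direction, for instance with a methoxy or a butoxy group in place of ethoxy.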